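The source may hold more compounds than are shown below. What is called first, only, known or untested is meant among the compounds shown, and "the series" means these compounds.

For the measured compounds named here, in a functional assay on MCF7 cells (Homo sapiens) for cytotoxicity, read by MTT assay, with a stated time of 48 h (a lower number here means a stronger inhibitor, a higher number a weaker inhibitor), compound 3 `COc1cc(-c2nnc3n2NC(c2ccco2)C(C(=O)c2ccc(F)c(F)c2)S3)cc(OC)c1OC` is the one compound of the three that gives a number, namely 73200 nM. Compound 1 `COc1cc(-c2nnc3n2NC(c2ccco2)C(C(=O)c2cccs2)S3)cc(OC)c1OC` returns only a limit of the assay, > 100000 nM, and not a number. Compound 2 `COc1cc(-c2nnc3n2NC(c2ccco2)C(C(=O)c2ccc(Cl)cc2)S3)cc(OC)c1OC` likewise returns only a limit, > 100000 nM. Two of the three values thus rest at the limit of > 100000 nM in this assay, at which 2 of the 3 values shown sit. Compound 4 `COc1cc(-c2nnc3n2NC(c2ccco2)C(C(=O)c2cccc(Br)c2)S3)cc(OC)c1OC` differs from compound 3 in one place: 3-bromophenyl in place of 3,4-difluorophenyl on a carbonyl carbon. Going by the values given here, two measured steps bear on this change. The step of an at least 1.3-fold lower number from compound 2 to compound 3 (0.13 log units; that floor lies within the scatter) exchanges one halogenated phenyl for another on the same carbonyl carbon, and the step of an at least 1.3-fold lower number from compound 1 to compound 3 (0.13 log units; that floor lies within the scatter) also ends at the 3,4-difluorophenyl; both floors lie within the scatter, so neither shows a change that can be read as beyond it. The change to compound 4 is again one halogenated phenyl for another on that carbonyl carbon, and in this assay a step toward a higher number, of a size not beyond the scatter, is expected, with a real chance that only a limit is reported. Compound 4 is therefore expected to give about 100000 nM, within the range 40000 nM to 300000 nM. This expectation means a step of a 1.4-fold higher number from compound 3 to compound 4 (0.14 log units; within the scatter).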

Compound 4, half-maximal inhibitory concentration: 91800 nM
Compound 4: the middle estimate sits 1.1-fold (0.04 log units) above what was measured, within the range that was stated.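

In this assay, for the compounds shown here, the carbonyl carbon now carries a second halogenated phenyl that returns a number and not a limit, so this position can be read as a true comparison for the first time, as a 1.3-fold higher number from compound 3 to compound 4 (0.10 log units; within the scatter) shows. The exchange of 3,4-difluorophenyl for 3-bromophenyl therefore stays within the scatter, and compound 3 and compound 4 cannot be put in any order. The steps of an at least 1.0-fold lower number from compound 2 to compound 4 (0.03 log units; that floor lies within the scatter) and an at least 1.0-fold lower number from compound 1 to compound 4 (0.03 log units; that floor lies within the scatter) rest on floors within the scatter, so they do not separate compound 4 from the two compounds that gave only a limit: the limit of > 100000 nM in this assay, at which 2 of the 4 values shown sit.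

The compounds shown carry only halogenated phenyl groups and a thiophen-2-yl on this carbonyl carbon, so it remains open what an amine, a carboxylic acid or a longer alkyl chain would do there. Going by these compounds, it also remains open whether any group at this position can give a number beyond the scatter from compound 3, and whether a change elsewhere on the shared core would do so.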